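A few compounds are considered here, and "the series" means these few. Any claim that something is new, unique, unknown or untested is made for them only; others in the source may bear on it.

Measured in an assay on 1321N1 cells for antagonist activity at P2Y purinoceptor 6 (Homo sapiens), read by FLIPR and calcium flux; a lower number here means a stronger inhibitor, a higher number a weaker inhibitor:
Compound 1 `O=[N+]([O-])C1=Cc2cc(C#Cc3ccc(C(F)(F)F)cc3)ccc2OC1C(F)(F)F`: 5220 nM
Compound 2 `O=[N+]([O-])C1=Cc2cc(F)ccc2OC1C(F)(F)F`: 1150 nM
Compound 3 `O=[N+]([O-])C1=Cc2cc(F)cc(Br)c2OC1C(F)(F)F`: 3990 nM

Compound 1 has the highest number of the three; its gap to compound 3 lies within the scatter, while its gap to compound 2 lies beyond it. Compound 4 `O=[N+]([O-])C1=Cc2cc(C#Cc3ccc(F)cc3)ccc2OC1C(F)(F)F` differs from compound 1 by fluoro in place of trifluoromethyl on an aromatic carbon. Among the compounds with values here, the only measured step, a 3.5-fold higher number from compound 2 to compound 3 (0.54 log units; beyond the scatter), concerns a different change on the shared core and does not bear directly on this one. Within the data shown here, with no comparable step available, no shift beyond the scatter is expected in this assay. Compound 4 is therefore estimated at 4000 nM, with a range from 1500 nM to 12000 nM. This estimate corresponds to an expected 1.3-fold lower number from compound 1 to compound 4 (0.12 log units; within the scatter).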

Compound 4, half-maximal inhibitory concentration: 8860 nM
Compound 4: middle estimate off by 2.2-fold (0.35 log units), on the low side; measured number inside the range.
By their numbers in this assay, from the lowest: compound 2; then compounds 3, 1 and 4 (each within the scatter of the next, the first and the last beyond it).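

In this assay the exchange of trifluoromethyl for fluoro on this aromatic carbon, para to a large group, gives a 1.7-fold higher number from compound 1 to compound 4 (0.23 log units; within the scatter) and so no shift that can be told from the scatter. Within the data shown here, the only earlier step, a 3.5-fold higher number from compound 2 to compound 3 (0.54 log units; beyond the scatter) for bromo in place of hydrogen elsewhere on the shared core, lies beyond the scatter, so this position is the first seen to accept a change of group without a clear shift. No measurement is available that would explain this result.

From the compounds shown here alone, whether an amine, a carboxylic acid or a methoxy group at this position would move the number remains open.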